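The source may hold more compounds than are shown below. What is called first, only, known or untested is meant among the compounds shown, and "the series" means these compounds.

Of the compounds shown here, three sharing one core have been measured in an ADME assay on L929 cells (Mus musculus) for cytotoxicity, read by resazurin assay, with a stated time of 48 h; a lower number here means that less compound is tolerated, a higher number that more compound is tolerated. Compound 1 (`O=c1c2cc([N+](=O)[O-])ccc2n(CCCBr)n1Cc1ccccc1`) gives 25200 nM, and compound 2 (`COC(=O)Cn1c2ccc([N+](=O)[O-])cc2c(=O)n1Cc1ccccc1`) gives 129000 nM. Compound 3 (`O=c1c2cc([N+](=O)[O-])ccc2n(CCO)n1Cc1ccccc1`) reaches only a limit of the assay, > 256000 nM. The next structure, compound 4 (`O=C(c1ccccc1)n1c2ccc([N+](=O)[O-])cc2c(=O)n1Cc1ccccc1`), carries benzoyl in place of 2-hydroxyethyl on an aromatic nitrogen. For the measured compounds named here, no measured step brings a benzoyl to that nitrogen, so the evidence is indirect. The changes on the chain show an at least 10-fold higher number from compound 1 to compound 3 (1.00 log units; beyond the scatter) and a 5.1-fold higher number from compound 1 to compound 2 (0.71 log units; beyond the scatter), while the remaining comparison gives an at least 1.9-fold higher number from compound 2 to compound 3 (0.29 log units; that floor lies within the scatter). Going by the values given here, compound 2, at 129000 nM, is the only measured compound with a carbonyl in this group and serves as the nearest guide. A modest fall in the number is therefore expected in this assay, although another limit result remains possible. The estimate amounts to an expected at least 3.6-fold lower number from compound 3 to compound 4 (0.56 log units; beyond the scatter). Compound 4 is estimated at 70000 nM, with an expected range of 18000 nM to 220000 nM.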

Compound 4, concentration lethal to 50% of the cells: 146000 nM
Compound 4: middle estimate off by 2.1-fold (0.32 log units), on the low side; low and high end bracket the measured number.
By their numbers in this assay, from the lowest: compound 1; then compounds 2 and 4 (each within the scatter of the next). At a limit, above all of these: compound 3.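

In this assay, benzoyl on the aromatic nitrogen reads level with (methoxycarbonyl)methyl, with a 1.1-fold higher number from compound 2 to compound 4 (0.05 log units; within the scatter), so a group bringing a six-membered aromatic ring of carbon only to this nitrogen stands no apart from the ester-bearing chain. Against 3-bromopropyl the same change gives a 5.8-fold higher number from compound 1 to compound 4 (0.76 log units; beyond the scatter), which places benzoyl, like (methoxycarbonyl)methyl, clear of compound 1. The comparison with 2-hydroxyethyl, an at least 1.7-fold lower number from compound 3 to compound 4 (0.24 log units; that floor lies within the scatter), is only a floor and rests on the limit of compound 3: the limit of > 256000 nM in this assay, at which 1 of the 4 values shown sits.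

The compounds shown leave open how an amine, a carboxylic acid or a longer chain ending in hydroxy on this nitrogen would read in this assay. They also leave open how large the true step from 2-hydroxyethyl to benzoyl is.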